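Sulfonyl aryl variation on the piperidinyl azaindole series

The compounds below may be only part of what the source reports. "The series", "measured", "known", "first", "only" and "open" are said of these compounds alone.

Measured compounds
- compound 1: `O=S(=O)(c1ccccc1)c1cn(C2CCCNC2)c2ncccc12` — 47 nM
- compound 2: `O=S(=O)(c1cccc(F)c1)c1cn(C2CCCNC2)c2ncccc12` — 67 nM

Both values come from a functional assay on HeLa cells for agonist activity at 5-hydroxytryptamine receptor 6 (Homo sapiens), read by cAMP accumulation and immunoassay; a higher number here means that more compound is needed for the effect, a lower number that less compound is needed. Compound 2 stands at the higher of the two numbers; its nearest neighbour is compound 1, and the step of a 1.4-fold higher number from compound 1 to compound 2 (0.15 log units; within the scatter) lies within the scatter, so the two compounds cannot be ordered.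

The next compound is compound 3, `O=S(=O)(c1cc(Cl)cc(Cl)c1)c1cn(C2CCCNC2)c2ncccc12`. Relative to compound 2 the change is 3,5-dichlorophenyl in place of 3-fluorophenyl on a sulfonyl sulfur. Within the data shown here, the only step that bears on it is the one from compound 1 to compound 2, a single halogen added to the phenyl ring, which gave a 1.4-fold higher number from compound 1 to compound 2 (0.15 log units; within the scatter) and thus no effect beyond the scatter. Among the measured compounds shown here, compound 3 carries two chlorines where compound 2 carries one fluorine, a larger change with no measured precedent in this set. A modest step of a 1.5-fold higher number from compound 2 to compound 3 (0.17 log units; within the scatter) toward a higher number is expected, but it may well stay within the scatter. For compound 3 the estimate in this assay is 100 nM, with a range from 30 nM to 350 nM.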

Compound 3, half-maximal effective concentration: 297 nM
The estimate for compound 3 lay 3.0-fold (0.47 log units) below the measured number; the range from low to high includes it.
By their numbers in this assay, from the lowest: compounds 1 and 2 (each within the scatter of the next); then compound 3.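

In this assay, the aryl group on the sulfonyl sulfur now shows that it can shift the number: 3,5-dichlorophenyl in place of 3-fluorophenyl gives a 4.4-fold higher number from compound 2 to compound 3 (0.65 log units; beyond the scatter), and 3,5-dichlorophenyl in place of phenyl gives a 6.3-fold higher number from compound 1 to compound 3 (0.80 log units; beyond the scatter). Among these compounds, these are the only steps in the set beyond the scatter, so a change at this place is not always silent, and compound 3 stands apart from the other two, which cannot be ordered. No supporting measurement is available to explain the shift.

The two chlorines change both the kind and the number of halogens at once, so a phenyl carrying a single chlorine or two fluorines would be needed to separate them. As far as these compounds go, whether a methoxy group or an amine on the ring would move the number in the same direction also remains open.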